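Carbonyl-side ring variation: estimating compound 4

The source may hold more compounds than are shown below. What is called first, only, known or untested is meant among the compounds shown, and "the series" means these compounds.

Within the data shown here, compound 3 `COc1ccc(/C=C/c2cc(OC)cc(OC)c2/C=C/C(=O)c2ccc(C)cc2C)cc1` gives 0.9 ug/mL in a functional assay on HepG2 cells (Homo sapiens) for antiproliferative activity, read by MTT assay, with a stated time of 48 h (on this read-out lower numbers stand for stronger inhibition and higher numbers for weaker inhibition), the lowest of the three numbers so far. Compound 1 `COc1ccc(/C=C/c2cc(OC)cc(OC)c2/C=C/C(=O)c2ccccc2)cc1` gives 6.8 ug/mL and compound 2 `COc1ccc(/C=C/c2cc(OC)cc(OC)c2/C=C/C(=O)c2ccc(Cl)c(Cl)c2)cc1` gives 10.8 ug/mL; the step of a 1.6-fold higher number from compound 1 to compound 2 (0.20 log units; within the scatter) keeps these two together, while a 7.6-fold lower number from compound 1 to compound 3 (0.88 log units; beyond the scatter) and a 12-fold lower number from compound 2 to compound 3 (1.08 log units; beyond the scatter) set compound 3 apart. Compound 4 `COc1ccc(/C=C/c2cc(OC)cc(OC)c2/C=C/C(=O)c2ccc(-c3ccccc3)cc2)cc1` carries 4-phenylphenyl in place of 2,4-dimethylphenyl on a carbonyl carbon. Among the measured compounds shown here, no measured step introduces 4-phenylphenyl, so the only guide is that compound 1 and compound 2, both lacking 2,4-dimethylphenyl, sit well behind compound 3. Compound 4 is therefore expected to move back toward the level of compound 1, an estimated step of a 5.6-fold higher number from compound 3 to compound 4 (0.74 log units; beyond the scatter). The estimate for compound 4 is 5 ug/mL, with a range from 1.5 ug/mL to 15 ug/mL.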

Compound 4, half-maximal inhibitory concentration: 10.5 ug/mL
Estimate against measurement, compound 4: 2.1-fold (0.32 log units) below; measured number inside the range.
By their numbers in this assay, from the lowest: compound 3; then compounds 1, 4 and 2 (each within the scatter of the next).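

In this assay, phenyl in place of hydrogen on the carbonyl-side ring leaves the number within the scatter: a 1.5-fold higher number from compound 1 to compound 4 (0.19 log units; within the scatter). Swapping 3,4-dichlorophenyl for 4-phenylphenyl does the same, a 1.0-fold lower number from compound 2 to compound 4 (0.01 log units; within the scatter), so these three compounds sit together, while a 12-fold higher number from compound 3 to compound 4 (1.07 log units; beyond the scatter) leaves 2,4-dimethylphenyl alone among the four groups at this place. Nothing available explains this separation.

Still open, as far as these compounds go, is whether 2-methylphenyl or 4-methylphenyl alone would match 2,4-dimethylphenyl. From the compounds shown here alone, how an amine or a carboxylic acid on this ring would read out also remains open.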